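A few compounds are considered here, and "the series" means these few. Any claim that something is new, unique, unknown or untested is made for them only; others in the source may bear on it.

In a physicochemical assay for solubility, at pH 7.4 (a higher number here means a more soluble compound, a lower number a less soluble compound), the measured compounds give:

Compound 3 `CCc1cc(C)nn1-c1nc(C(F)(F)F)cc(=O)[nH]1`: 200000 nM
Compound 1 `Cc1cc(C)n(-c2nc(-c3ccc(NS(C)(=O)=O)cc3)cc(=O)[nH]2)n1`: 20000 nM
Compound 2 `Cc1cc(C)n(-c2nc(-c3ccc(S(C)(=O)=O)cc3)cc(=O)[nH]2)n1`: 8000 nM

Compound 3 has the highest number of the three, with compound 1 and compound 2 both lower by gaps beyond the scatter. Compound 4 `Cc1cc(Nc2ccc(F)cc2)n(-c2nc(C(F)(F)F)cc(=O)[nH]2)n1` differs from compound 3 by (4-fluorophenyl)amino in place of ethyl on an aromatic carbon. Within the data shown here, only one measured step exists, a 2.5-fold lower number from compound 1 to compound 2 (0.40 log units; beyond the scatter), and it concerns a change on the other aromatic ring of a different core, so it does not bear on this step. The change here is therefore untested; with a far larger group entering, a step downward beyond the scatter is expected, with wide uncertainty. Compound 4 is expected to give 20000 nM, within a range from 3000 nM to 100000 nM. This estimate means an expected step of a 10-fold lower number from compound 3 to compound 4 (1.00 log units; beyond the scatter).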

Compound 4, solubility: 15000 nM
For compound 4 the middle estimate is 1.3-fold (0.12 log units) above the measured one; the measured number falls inside the stated range.
By their numbers in this assay, from the lowest: compounds 2, 4 and 1 (each within the scatter of the next, the first and the last beyond it); then compound 3.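

Putting (4-fluorophenyl)amino in place of ethyl on this aromatic carbon gives a 13-fold lower number from compound 3 to compound 4 (1.12 log units; beyond the scatter) in this assay and shows that the read-out depends strongly on what this carbon carries. Among these compounds, this is the first measured change at this position, and it is a large one. No measurement shown explains the size of this drop.

As far as these compounds go, it remains open which part of the new group matters: the nitrogen link, the aromatic ring or the fluorine. A simple amine, a phenyl group or an unsubstituted phenylamino group at this carbon would help separate them.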